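Second chloro on the aryl ring of compound 1

A few compounds are considered here, and "the series" means these few. Any claim that something is new, unique, unknown or untested is made for them only; others in the source may bear on it.

Working notes on the series. Compound 1 `O=CN1CCN(c2ccc(Cl)cc2)C1=S` stands at the lower of the two numbers in hand. In a functional assay on K562 cells (Homo sapiens) for inhibition, read by sulforhodamine B assay, with a stated time of 48 h (a higher number here means a weaker inhibitor of growth, a lower number a stronger inhibitor of growth), compound 1 gives 12900 nM. Within the data shown here, compound 2 `COc1cc(C(=O)N2CCN(C=O)C2=S)cc(OC)c1OC`, the only other member measured, gives 30800 nM in this assay, a number that lies beyond the scatter from that of compound 1. Among the measured compounds shown here, no pair of measured compounds differs in a single place, so no step size is known from the data themselves.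

Compound 3 `O=CN1CCN(c2ccc(Cl)c(Cl)c2)C1=S` is to be measured in this assay. It differs from compound 1 by chloro in place of hydrogen on an aromatic carbon. Nothing in hand shows what a change at this place does in this assay, so the expectation rests on compound 1 alone. The expected step, a 1.4-fold lower number from compound 1 to compound 3 (0.13 log units; within the scatter), is small, in either direction, and not beyond the usual scatter. For compound 3 a value of 9500 nM is expected, within a range from 3200 nM to 28000 nM.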

Compound 3, concentration for 50% growth inhibition: 13800 nM
Compound 3: the middle estimate sits 1.5-fold (0.16 log units) below what was measured; low and high end bracket the measured number.
By their numbers in this assay, from the lowest: compounds 1 and 3 (each within the scatter of the next); then compound 2.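

Chloro in place of hydrogen on an aromatic carbon, ortho to a chloro group and meta to a group of 8 heavy atoms, gives a 1.1-fold higher number from compound 1 to compound 3 (0.03 log units; within the scatter) in this assay as the first step in the series measured at a single place. At this position, the added chloro does not separate the two compounds, so the step size that was missing from the data now has one reading, and it lies within the scatter. No measurement in hand accounts for the two numbers standing so close together.

Among these compounds, whether this position is as indifferent to other groups remains open, since chloro is the only group seen there. An amine or a carboxylic acid on the same aromatic carbon would show whether a group other than chloro gives a step beyond the scatter.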